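This account rests on a few compounds, and the source may have more. Where it says the series, first, only, none or still open, it means among the compounds named here.

Measured so far in a functional assay on HeLa cells (Homo sapiens) for antiproliferative activity, read by MTT assay, with a stated time of 48 h; on this read-out lower numbers stand for stronger inhibition and higher numbers for weaker inhibition:
compound 1, `CCN(CC)CCCCn1c(N)c(-c2nc3ccccc3[nH]2)c2nc(C#N)c(C#N)nc21`: 10100 nM
compound 2, `CN(C)CCCCCn1c(N)c(-c2nc3ccccc3[nH]2)c2nc(C#N)c(C#N)nc21`: 10800 nM
compound 3, `CCN(CC)CCCn1c(N)c(-c2nc3ccccc3n2C)c2nc(C#N)c(C#N)nc21`: 12400 nM

The three numbers lie close together, and none of the gaps between them goes beyond the scatter of this assay. From compound 1 to compound 2 the change is (dimethylamino)methyl in place of diethylamino on a saturated chain carbon, four bonds along the chain from an aromatic nitrogen, and it made a 1.1-fold higher number from compound 1 to compound 2 (0.03 log units; within the scatter). Compound 3 and compound 1 have the same atoms joined differently; the difference between the two cores is not broken down here.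

Compound 4, `CN(C)CCCCn1c(N)c(-c2nc3ccccc3n2C)c2nc(C#N)c(C#N)nc21`, is not yet measured. From compound 3 it differs by (dimethylamino)methyl in place of diethylamino on a saturated chain carbon, three bonds along the chain from an aromatic nitrogen. This is the same kind of change as from compound 1 to compound 2, but the place is not the same word for word: there the group sits four bonds along the chain from an aromatic nitrogen, here three bonds along the chain from an aromatic nitrogen. Since the earlier step was a 1.1-fold higher number from compound 1 to compound 2 (0.03 log units; within the scatter), the step from compound 3 to compound 4 is expected to be similarly small, a 1.0-fold higher number from compound 3 to compound 4 (0.00 log units; within the scatter). Compound 4 is therefore estimated to give 12500 nM in this assay, with a likely range from 6000 nM to 26000 nM.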

Compound 4, half-maximal inhibitory concentration: 460 nM
The estimate for compound 4 lay 27-fold (1.43 log units) above the measured number, and the stated range ends above it.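

In this assay, putting (dimethylamino)methyl in place of diethylamino on the core of compound 3 gives a 27-fold lower number from compound 3 to compound 4 (1.43 log units; beyond the scatter). This change therefore cannot be carried from the core of compound 1 to the core of compound 3 with its size intact, since the two steps disagree: the same change on two cores in this assay, a 1.1-fold higher number (0.03 log units; within the scatter) from compound 1 to compound 2 and a 27-fold lower number (1.43 log units; beyond the scatter) from compound 3 to compound 4, 29-fold (1.46 log units) apart, beyond the scatter of two such steps The comparison rests on two pairs only, and they differ in the place of the change as well as in the core, four bonds along the chain from an aromatic nitrogen in one pair and three bonds in the other, so it gives no general rule, does not separate core from place, and offers no reason for the gap.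

Going by these compounds, it remains open which difference between the two pairs goes with the large step. Also open, on these data alone, is whether the step on the core of compound 3 persists with a cyclic amine such as pyrrolidine or morpholine in place of dimethylamino, or with a longer chain than 4-(dimethylamino)butyl.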